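A few compounds are considered here, and "the series" means these few. Any claim that something is new, unique, unknown or untested is made for them only; others in the source may bear on it.

Measured in a functional assay on HeLa cells (Homo sapiens) for antiproliferative activity, read by sulforhodamine B assay, with a stated time of 72 h; on this read-out lower numbers stand for stronger inhibition and higher numbers for weaker inhibition:
- Compound 1 `N#Cc1ccc(NC(=S)N/N=C/c2ccc3ccccc3n2)cc1`: 20000 nM
- Compound 2 `S=C(NCc1ccccc1)N/N=C/c1ccc2ccccc2n1`: 62800 nM
- Compound 3 `S=C(N/N=C/c1ccc2ccccc2n1)Nc1ccccc1Br`: > 100000 nM, a limit and not a number

Compound 3 stands at the limit of > 100000 nM in this assay, at which 1 of the 3 values shown sits. In compound 4 `S=C(N/N=C/c1ccc2ccccc2n1)Nc1ccc(Br)cc1`, 4-bromophenyl stands in place of 2-bromophenyl on an amide-type nitrogen (4-bromophenyl in place of 2-bromophenyl on an amide-type nitrogen). Among the measured compounds shown here, no measured step tests this exchange directly. The nearest steps are changes on the same nitrogen: a 3.1-fold higher number from compound 1 to compound 2 (0.50 log units; beyond the scatter) is modest and an at least 5.0-fold higher number from compound 1 to compound 3 (0.69 log units; beyond the scatter) is at least modest, while the floor of an at least 1.5-fold higher number from compound 2 to compound 3 (0.20 log units; that floor lies within the scatter) lies within the scatter. A modest step in this assay is therefore expected, toward a lower number, as only a limit is known for compound 3. The expected step is an at least 2.5-fold lower number from compound 3 to compound 4 (0.39 log units; beyond the scatter). Compound 4 is estimated at 40000 nM, with an expected range of 13000 nM to 100000 nM.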

Compound 4, half-maximal inhibitory concentration: 56800 nM
For compound 4 the middle estimate is 1.4-fold (0.15 log units) below the measured one; low and high end bracket the measured number.
By their numbers in this assay, from the lowest: compound 1; then compounds 4 and 2 (each within the scatter of the next). At a limit, above all of these: compound 3.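

With 4-bromophenyl in place of 2-bromophenyl on the amide-type nitrogen, the step is an at least 1.7-fold lower number from compound 3 to compound 4 (0.24 log units; that floor lies within the scatter), so the size of this exchange remains unsettled. Compound 3 is known only through a limit, not a number: the limit of > 100000 nM in this assay, at which 1 of the 4 values shown sits. The clearer finding is that 4-bromophenyl and benzyl on this nitrogen cannot be told apart, with a 1.1-fold lower number from compound 2 to compound 4 (0.04 log units; within the scatter), whereas bromo in place of cyano on the aromatic carbon gives a 2.8-fold higher number from compound 1 to compound 4 (0.45 log units; beyond the scatter).

The compounds shown leave open how an amine or a carboxylic acid in place of that bromo or cyano would read out.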